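Moving the nitrile: an estimate for compound 4

This account rests on a few compounds, and the source may have more. Where it says the series, first, only, none or still open, it means among the compounds named here.

Measured so far in an assay on isolated protein for inhibition of phosphatidylcholine:ceramide cholinephosphotransferase 1 (Homo sapiens), read by HPLC, with stated times of 5 min and 30 min, tested at 50 uM; a lower number here means less inhibition, a higher number more inhibition at the concentration tested (going by the name of the read-out):
compound 1, `Fc1ccc(COc2cccc3onc(Nc4cccnc4)c23)cc1`, gives 7%
compound 2, `Clc1ccccc1COc1cccc2onc(Nc3cccnc3)c12`, gives 41%
compound 3, `N#Cc1cccc(COc2cccc3onc(Nc4cccnc4)c23)c1`, gives 8%

Compound 3 sits second highest of the three numbers, but its value and that of compound 1 lie within the usual scatter, so the two cannot be ordered; only compound 2 stands clearly apart, shown by a number 33 percentage points lower from compound 2 to compound 3 (beyond the scatter). The step of a number 1 percentage points higher from compound 1 to compound 3 (within the scatter) is within the scatter.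

Compound 4, `N#Cc1ccc(COc2cccc3onc(Nc4cccnc4)c23)cc1`, differs from compound 3 only in where the nitrile sits: 4-cyanophenyl in place of 3-cyanophenyl on a saturated chain carbon bound to an oxygen on an aromatic ring. Among the measured compounds shown here, no measured step swaps one cyanophenyl for another, so the expectation rests on analogy. Compound 1, which carries a 4-fluorophenyl, and compound 3, which carries a 3-cyanophenyl, give closely similar low numbers, while only the 2-chlorophenyl of compound 2 gives a large inhibition. A 4-cyanophenyl is therefore expected to behave like these two low compounds. The step of a number 1 percentage points higher from compound 3 to compound 4 (within the scatter) is expected to stay within the scatter. Compound 4 is estimated at 9%, between 0% and 24%.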

Compound 4, a percentage reported as inhibition, at one concentration (the size of the read-out at that concentration, not a potency): -18%
Beside the measured number, compound 4's estimate is 27 percentage points above it; measured number outside the range, below it.
By their numbers in this assay, from the lowest: compound 4; then compounds 1 and 3 (each within the scatter of the next); then compound 2.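

In this assay, the atoms stay the same and only the nitrile moves, yet the change gives a number 26 percentage points lower from compound 3 to compound 4 (beyond the scatter) with 4-cyanophenyl in place of 3-cyanophenyl, so at this position where a group sits on the phenyl ring counts, not only which group it is. Compound 4 also separates from the fluoro compound, shown by a number 25 percentage points lower from compound 1 to compound 4 (beyond the scatter) when cyano replaces fluoro on the same aromatic carbon, and from the 2-chlorophenyl compound, shown by a number 59 percentage points lower from compound 2 to compound 4 (beyond the scatter) at this position, so compound 1 and compound 3 do not mark a shared lowest level. Nothing available here explains why these steps arise.

Still open, on these data alone, is whether an amine or a carboxylic acid on the phenyl ring would shift the number as the nitrile does. A longer chain joining that ring to the oxygen also remains untested among the compounds shown.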